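Diacylhydrazine sulfonamides: from arylhydrazide to fluorobenzoyl

A few compounds are considered here, and "the series" means these few. Any claim that something is new, unique, unknown or untested is made for them only; others in the source may bear on it.

The series is followed in a functional assay on SGC-7901 cells (Homo sapiens) for antiproliferative activity, read by MTT assay, with a stated time of 24 h; a lower number here means a stronger inhibitor, a higher number a weaker inhibitor. Compound 1 `Cc1ccccc1NNC(=O)c1ccccc1NS(=O)(=O)c1cnc(O)nc1O` reaches only the assay limit there, giving > 20000 nM. Two further members carry a second carbonyl on the hydrazine. Compound 2 `O=C(NNC(=O)c1ccccc1Cl)c1ccc(NS(=O)(=O)c2cnc(O)nc2O)cc1` in this assay gives 3240 nM. Compound 3 `O=C(NNC(=O)c1cccc(NS(=O)(=O)c2cnc(O)nc2O)c1)c1ccc(F)cc1` in this assay returns only a limit, > 20000 nM. Compound 1 thus stands at the limit rather than at a number; two of the three values shown do so, as the limit of > 20000 nM in this assay, at which 2 of the 3 values shown sit, records. No pair of these compounds differs in a single place, so no step between measured compounds is known, and no size of step has been observed.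

Compound 4 `O=C(NNC(=O)c1ccccc1NS(=O)(=O)c1cnc(O)nc1O)c1ccccc1F` is not yet measured. The difference from compound 1 is counted as (2-fluorophenyl)carbonyl in place of 2-methylphenyl on an amine nitrogen. The change brings compound 4 to the diacylhydrazine pattern shared by compound 2 and compound 3; those two sit on either side of the limit, so that pattern alone does not fix the outcome. The expected step from compound 1 of an at least 1.6-fold lower number from compound 1 to compound 4 (0.22 log units; that floor lies within the scatter) in this assay is taken as a modest move toward stronger inhibition, with a limit remaining a real possibility. Compound 4 is estimated at 12000 nM, within 3000 nM to 40000 nM.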

Compound 4, half-maximal inhibitory concentration: > 20000 nM
Compound 4 ended at the assay's limit (the forecaster's own chance of this, stated with the estimate: 45%); middle value at least 1.6-fold (0.22 log units) away from the limit.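

In this assay, for the compounds shown here, compound 1 and compound 4 both stand at a limit and not at a number, so no step from compound 1 to compound 4 can be read: the limit of > 20000 nM in this assay, at which 3 of the 4 values shown sit.

The compounds shown leave open which structural difference sets compound 2 apart from compound 3 and compound 4, since no pair among them differs in a single place.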